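The compounds below may be only part of what the source reports. "The series", "measured", "known", "first", "only" and "open" are said of these compounds alone.

In a functional assay on HCT-116 cells (Homo sapiens) for cytotoxicity, read by MTT assay (on this read-out lower numbers stand for stronger inhibition and higher numbers for weaker inhibition), compound 2 `CCn1cc(C(=O)Nc2cccc([N+](=O)[O-])c2)c(=O)c2cc(F)c(N3CCNC(C)C3)c(F)c21` gives 2710 nM, and compound 1 `CCn1cc(C(=O)Nc2ccc(Cl)cn2)c(=O)c2cc(F)c(N3CCNC(C)C3)c(F)c21` gives 3300 nM; the two lie within the scatter of each other, as the step of a 1.2-fold lower number from compound 1 to compound 2 (0.09 log units; within the scatter) shows. Compound 3 `CCn1cc(C(=O)Nc2cc([N+](=O)[O-])ccc2F)c(=O)c2cc(F)c(N3CCNC(C)C3)c(F)c21` differs from compound 2 by fluoro in place of hydrogen on an aromatic carbon. For the measured compounds named here, the one measured step exchanges the whole aryl group and stays within the scatter, and no measured step adds a fluoro to this ring, so for compound 3 a change of a 1.0-fold lower number from compound 2 to compound 3 (0.00 log units; within the scatter) in this assay is expected, nothing beyond the scatter. Compound 3 is therefore estimated at 2700 nM, within a range from 1200 nM to 6000 nM.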

Compound 3, half-maximal inhibitory concentration: 2600 nM
For compound 3 the middle estimate is 1.0-fold (0.02 log units) above the measured one; the range from low to high includes it.
By their numbers in this assay, from the lowest: compounds 3, 2 and 1 (each within the scatter of the next).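

The step of a 1.0-fold lower number from compound 2 to compound 3 (0.02 log units; within the scatter) in this assay shows that this ring position, ortho to a large group and para to a nitro group, accepts fluoro in place of hydrogen with no difference beyond the scatter. The 2-fluoro-5-nitrophenyl amide also stays within the scatter of the 5-chloropyridin-2-yl amide, at a 1.3-fold lower number from compound 1 to compound 3 (0.10 log units; within the scatter). No further data bear on this result.

From the compounds shown here alone, whether a larger group at this position, such as methoxy or an amine, would give a similar value remains open. So does whether removing the nitro group from the fluorinated ring would matter.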